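Isopropyl in Place of 4-Bromophenyl on an Aromatic Nitrogen

This account rests on a few compounds, and the source may have more. Where it says the series, first, only, none or still open, it means among the compounds named here.

Three compounds have so far been measured in an ADME assay on Huh-7 cells (Homo sapiens) for cytotoxicity; on this read-out higher numbers stand for lower toxicity in this test and lower numbers for higher toxicity in this test:
Compound 1, `Cc1ccccc1CNc1nn(-c2ccc(F)cc2F)cc1CNCCN1CCN(C)CC1`: > 20000 nM.
Compound 2, `Cc1ccccc1-c1nn(-c2ccc(Br)cc2)cc1CNCCN1CCN(C)CC1`: 9600 nM.
Compound 3, `CCCN1CCC(CNCc2cn(-c3ccc([N+](=O)[O-])cc3)nc2-c2ccc(C(F)(F)F)cc2)CC1`: 2300 nM.

For compound 1 the result is the limit of > 20000 nM in this assay, at which 1 of the 3 values shown sits, which is a limit of the assay and not a number. Among the two values that are numbers, compound 2 holds the higher one; compound 3 lies below it by a gap beyond the scatter. No two of these compounds differ in one place only, so no measured step exists.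

Compound 4, `Cc1ccccc1-c1nn(C(C)C)cc1CNCCN1CCN(C)CC1`, differs from compound 2 by isopropyl in place of 4-bromophenyl on an aromatic nitrogen. The measured compounds carry no direct guide for such a change on that aromatic nitrogen, since compound 1 gives only a limit and compound 3 differs from compound 2 in several places at once. The step from compound 2 to compound 4 is therefore expected to be modest, a 1.5-fold higher number from compound 2 to compound 4 (0.16 log units; within the scatter), and is as likely to fall within the scatter as to go upward. Compound 4 is estimated to give 14000 nM, with a range from 5000 nM to 40000 nM.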

Compound 4, half-maximal cytotoxic concentration: > 20000 nM
Compound 4 gave a limit, no number (the forecaster's own chance of this, stated with the estimate: 35%); middle value at least 1.4-fold (0.15 log units) from the limit.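

In this assay, among the compounds shown here, isopropyl in place of 4-bromophenyl on the aromatic nitrogen gives an at least 2.0-fold higher number from compound 2 to compound 4 (0.31 log units; beyond the scatter), the first step that can be read at this position. For the compounds shown here, in this one pair, the six-membered aromatic ring and the bromine leave together and the number goes up, which the earlier compounds could not show. Compound 4 gives > 20000 nM, which is a limit of the assay and not a number, and it is not alone there: the limit of > 20000 nM in this assay, at which 2 of the 4 values shown sit.

Going by these compounds, what a plain phenyl or a methyl on this nitrogen would give remains open, and so does whether the ring or the bromine accounts for the step. Also open, on these data alone, is whether the same change would give a similar step with a group such as a 4-methoxyphenyl in place of the 2-methylphenyl group.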